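A few compounds are considered here, and "the series" means these few. Any claim that something is new, unique, unknown or untested is made for them only; others in the source may bear on it.

The account concerns two measured compounds and one that still awaits measurement. Compound 2 `COc1cc(NC(C)CCCN2C(=O)CN(C(=O)[C@@H](C)N)C2(C)C)c2ncccc2c1` is the more soluble of the pair: in a physicochemical assay for solubility (on this read-out higher numbers stand for higher solubility and lower numbers for lower solubility), compound 2 gives 120000 ug/mL, the highest of the two numbers. Among the measured compounds shown here, its only measured neighbour is compound 1 `COc1cc(NC(C)CCCN2C(=O)CN(C(=O)[C@H](N)CCSC)C2(C)C)c2ncccc2c1`, and in this assay compound 1 gives 11700 ug/mL. The step between them, a 10-fold higher number from compound 1 to compound 2 (1.01 log units; beyond the scatter), is a large one and lies well beyond the scatter.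

Compound 3 `COc1cc(NC(C)CCCN2C(=O)CN(C(=O)[C@H](N)CC(C)C)C2(C)C)c2ncccc2c1` is reached from compound 2 by a single change: isopropyl in place of hydrogen on a saturated chain carbon, two bonds along the chain from an amine nitrogen and a carbonyl carbon. For the measured compounds named here, no measured step shows this exact change, but the step from compound 1 to compound 2 bears on it, since it too concerns a small carbon-rich group on the same saturated chain carbon, and removing that group raised the number a great deal. Putting a group of comparable size back on is therefore expected to move the number the other way, by an amount estimated as a 6.0-fold lower number from compound 2 to compound 3 (0.78 log units; beyond the scatter). On that basis compound 3 is expected to give about 20000 ug/mL in this assay, within a range from 6000 ug/mL to 60000 ug/mL.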

Compound 3, solubility: 26600 ug/mL
The estimate for compound 3 lay 1.3-fold (0.12 log units) below the measured number; measured number inside the range.
By their numbers in this assay, from the lowest: compound 1; then compound 3; then compound 2.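

With isopropyl in place of hydrogen on this saturated chain carbon, this assay gives a 4.5-fold lower number from compound 2 to compound 3 (0.65 log units; beyond the scatter) and so a second, separate reading of what a group at this place does to the number. The group that enters does not take the number all the way back down, since replacing (methylsulfanyl)methyl with isopropyl gives a 2.3-fold higher number from compound 1 to compound 3 (0.36 log units; beyond the scatter) and this step too lies beyond the scatter. The three compounds therefore show that the number at this place depends on which group is present, not only on whether a group is present at all, with the hydrogen of compound 2 at the top of the series and both carbon-bearing chains lower.

The compounds shown carry only hydrogen and these two chains at this place, so how a carboxylic acid, a hydroxyl, a further amine, a ring or a longer chain would fall against them remains open. As far as these compounds go, it also remains open whether the order seen here would hold on a core other than the shared one, or in any read-out other than this one, and no available measurement accounts for the order of these three numbers.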